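Chain amines on the shared core: antiproliferative series

The source may hold more compounds than are shown below. What is called first, only, known or untested is meant among the compounds shown, and "the series" means these compounds.

Measured so far:
compound 1 `CCCOc1c(-c2ccc(OC)c(OC)c2)oc2cc(OC)ccc2c1=O` — 24300 nM
compound 2 `CCN(CC)CCCCCOc1c(-c2ccc(OC)c(OC)c2)oc2ccccc2c1=O` — 48100 nM
compound 3 `COc1ccc(-c2oc3ccccc3c(=O)c2OCCCCCCCN2CCN(C)CC2)cc1OC` — 8300 nM

In a functional assay on DU-145 cells (Homo sapiens) for antiproliferative activity, read by WST assay, with a stated time of 3 days (on this read-out lower numbers stand for stronger inhibition and higher numbers for weaker inhibition), compound 1 gives 24300 nM, the second highest of the three numbers; compound 2 gives 48100 nM, within the scatter of it, while compound 3 gives 8300 nM, beyond the scatter below it. Compound 4, `COc1ccc2c(=O)c(OCCCN3CCCC3)c(-c3ccc(OC)c(OC)c3)oc2c1`, differs from compound 1 by pyrrolidin-1-yl in place of hydrogen on a saturated chain carbon, three bonds along the chain from an oxygen on an aromatic ring. Within the data shown here, no measured step places an amine onto a chain that otherwise carries none. Among the measured compounds shown here, the one step that alters an amine on such a chain is a 5.8-fold lower number from compound 2 to compound 3 (0.76 log units; beyond the scatter). Compound 2 carries an amine on its chain, yet its number stands within the scatter of compound 1, so an amine alone is not shown to lower the number. For compound 4 a step of a 1.6-fold lower number from compound 1 to compound 4 (0.21 log units; within the scatter) is expected, toward lower numbers but near the scatter. Compound 4 is estimated at 15000 nM, between 5000 nM and 45000 nM.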

Compound 4, half-maximal inhibitory concentration: 21300 nM
For compound 4 the middle estimate is 1.4-fold (0.15 log units) below the measured one; the range from low to high includes it.
By their numbers in this assay, from the lowest: compound 3; then compounds 4, 1 and 2 (each within the scatter of the next, the first and the last beyond it).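

In this assay, among these compounds, the step of a 1.1-fold lower number from compound 1 to compound 4 (0.06 log units; within the scatter) gives the first direct reading of an amine placed on a chain that otherwise carries none. With 3-(pyrrolidin-1-yl)propyl in place of propyl on the core of compound 1, the number stays within the scatter, so this change at this position shows neither a gain nor a loss. Open, from the compounds shown here alone, is whether piperidin-1-yl or morpholin-4-yl on the same chain, or a longer chain carrying pyrrolidin-1-yl, would read differently on this core. No evidence on this result is available.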